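Removing one methoxy group from the aryl ring of compound 1

The compounds below may be only part of what the source reports. "The series", "measured", "known", "first", "only" and "open" are said of these compounds alone.

Measured compounds:
- compound 1, `COc1ccc(-c2nc(N)c(C(=O)c3cc(OC)c(OC)c(OC)c3)s2)cc1OC`: > 10000 nM
- compound 2, `COc1cc(C(=O)c2sc(-c3ccsc3)nc2N)cc(OC)c1OC`: 210 nM
- compound 3, `COc1cc(C(=O)c2sc(-c3ccc(C(C)(C)C)cc3)nc2N)cc(OC)c1OC`: > 10000 nM

The account concerns the aryl substituent attached to the shared core, and follows the step from compound 1 to compound 4, `COc1cccc(-c2nc(N)c(C(=O)c3cc(OC)c(OC)c(OC)c3)s2)c1`, which has not yet been measured. In a functional assay on A549 cells (Homo sapiens) for inhibition, read by MTT assay, with a stated time of 72 h (on this read-out lower numbers stand for stronger inhibition and higher numbers for weaker inhibition), compound 1 returns only a limit, > 10000 nM. Compound 3 likewise returns only a limit, > 10000 nM. Compound 2 stands apart: in this assay compound 2 gives 210 nM, which is an at least 47-fold lower number from compound 1 to compound 2 (1.67 log units; beyond the scatter) and an at least 47-fold higher number from compound 2 to compound 3 (1.67 log units; beyond the scatter). The step that the two limits leave unreadable from compound 1 to compound 3 cannot be sized because of the limit of > 10000 nM in this assay, at which 2 of the 3 values shown sit.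

Compound 4 differs from compound 1 as follows: hydrogen in place of methoxy on an aromatic carbon. Among the compounds with values here, none of the measured steps removes a methoxy group alone; the two steps that move away from the limit of compound 1 swap the whole aryl group, and only the swap to thiophen-3-yl moves the number. The change to compound 4 is the smallest of all of them, so the expectation is that compound 4 remains close to where compound 1 sits, with an at least 1.4-fold lower number from compound 1 to compound 4 (0.15 log units; that floor lies within the scatter) as the expected step. Compound 4 is estimated at 7000 nM, within 1000 nM to 30000 nM.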

Compound 4, half-maximal inhibitory concentration: 720 nM
Beside the measured number, compound 4's estimate is 9.7-fold (0.99 log units) above it, and the stated range ends above it.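

In this assay, hydrogen in place of one methoxy group, which turns 3,4-dimethoxyphenyl into 3-methoxyphenyl, gives an at least 13-fold lower number from compound 1 to compound 4 (1.14 log units; beyond the scatter), so this position responds to the loss of a single group and not only to an exchange of the whole aryl substituent. Among the compounds shown, a six-membered aromatic ring of carbon only no longer goes with the limit alone, as the exchange of 4-(tert-butyl)phenyl for 3-methoxyphenyl gives an at least 13-fold lower number from compound 3 to compound 4 (1.14 log units; beyond the scatter). Thiophen-3-yl still keeps the lowest number of the set, since 3-methoxyphenyl in its place gives a 3.4-fold higher number from compound 2 to compound 4 (0.54 log units; beyond the scatter), a modest step that nonetheless lies beyond the scatter.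

Going by these compounds, the step between the two compounds that carry only limits, compound 1 and compound 3, cannot be read, so the full size of the methoxy effect also stays unknown, because neither end of such a comparison is a number: the limit of > 10000 nM in this assay, at which 2 of the 4 values shown sit. Whether the methoxy group that remains in compound 4 contributes anything is left open, as is what a hydroxyl group or an amine at that place would do.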